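The source may hold more compounds than are shown below. What is called first, only, known or untested is meant among the compounds shown, and "the series" means these compounds.

In a functional assay on SH-SY5Y cells (Homo sapiens) for cytotoxicity, read by MTT assay, with stated times of 8 h, 30 min and 12 h, tested at 0.05 uM (on this read-out higher numbers stand for a stronger effect at the one concentration tested and lower numbers for a weaker effect), compound 2 `COc1ccc(CNC(=N)[C@@H]2CCC(=O)N2Cc2ccccc2[N+](=O)[O-])cc1` gives 18.1%, and compound 1 `N=C(NCc1ccccc1)[C@@H]1CCC(=O)N1Cc1ccccc1[N+](=O)[O-]` gives 10.1%, a pair that sit within the scatter of each other. Compound 3 `COc1ccc(CNC(=N)[C@@H]2CCC(=O)N2Cc2ccc(OC)cc2)cc1` differs from compound 2 by 4-methoxyphenyl in place of 2-nitrophenyl on a saturated chain carbon bound to an amide-type nitrogen in a ring. Going by the values given here, no measured step touches this part of the molecule; the only step known, a number 8 percentage points higher from compound 1 to compound 2 (within the scatter), concerns another position and stayed within the scatter, so it offers little guidance. With nothing in the data pointing either way, the expected step is a number 0.1 percentage points lower from compound 2 to compound 3 (within the scatter), none beyond the scatter. Compound 3 is therefore estimated at 18%, with a range from 5% to 32%.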

Compound 3, a percentage reported as activity, at one concentration (the size of the read-out at that concentration, not a potency): 24.2%
Estimate against measurement, compound 3: 6.2 percentage points below; low and high end bracket the measured number.
By their numbers in this assay, from the lowest: compounds 1, 2 and 3 (each within the scatter of the next, the first and the last beyond it).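

In this assay the change of 2-nitrophenyl to 4-methoxyphenyl on a saturated chain carbon bound to an amide-type nitrogen in a ring gives a number 6.1 percentage points higher from compound 2 to compound 3 (within the scatter) and so leaves the read-out within the scatter. Going by these compounds alone, this is the first view of this position, and it shows that the read-out does not depend on keeping 2-nitrophenyl there. No evidence bears on why the two groups compare as they do. As far as these compounds go, whether plain phenyl, or a phenyl carrying an amine or a carboxylic acid, would also stay within the scatter remains open, as does the read-out at any other concentration.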